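The source may hold more compounds than are shown below. What is called first, only, known or untested is meant among the compounds shown, and "the series" means these compounds.

Compound 1 `CC1(C)O[C@H]([C@H]2COC(C)(C)O2)[C@@H](C2CC(=O)SS2)O1` gives 16900 nM in a functional assay on HeLa cells (Homo sapiens) for cytotoxicity, read by MTT assay, in the presence of a further agent that is not named here; on this read-out higher numbers stand for weaker inhibition and lower numbers for stronger inhibition. Compound 2 `CC1(C)O[C@H]([C@H]2COC(C)(C)O2)[C@@H](C2CC(=O)S[S+]2[O-])O1` carries a group of 7 heavy atoms (3 carbon, 2 oxygen, 2 sulfur; one five-membered non-aromatic ring with 2 hetero atoms) in place of a group of 6 heavy atoms (3 carbon, 1 oxygen, 2 sulfur; one five-membered non-aromatic ring with 2 hetero atoms), on a saturated ring carbon, and in this assay compound 2 gives 12600 nM; the step is a 1.3-fold lower number from compound 1 to compound 2 (0.13 log units; within the scatter). Compound 3 `O=C1CC([C@H]2O[C@@H](n3ccc(=O)[nH]c3=O)[C@H](O)[C@@H]2O)SS1` is built on another core; how its core differs from that of compound 1 is not broken down here. In this assay compound 3 gives 20700 nM. Compound 4 `O=C1CC([C@H]2O[C@@H](n3ccc(=O)[nH]c3=O)[C@H](O)[C@@H]2O)[S+]([O-])S1` is compound 3 with a group of 7 heavy atoms (3 carbon, 2 oxygen, 2 sulfur; one five-membered non-aromatic ring with 2 hetero atoms) in place of a group of 6 heavy atoms (3 carbon, 1 oxygen, 2 sulfur; one five-membered non-aromatic ring with 2 hetero atoms), on a saturated ring carbon. This is the same kind of change as from compound 1 to compound 2, not the same one: here it sits on a five-membered non-aromatic ring with 1 oxygen, next to the ring atom that bears a hydroxy group, whereas before it sat on a ring with 2 oxygen, next to the ring atom that bears a group of 7 heavy atoms. For the measured compounds named here, because the only measured step of this kind is a 1.3-fold lower number from compound 1 to compound 2 (0.13 log units; within the scatter), compound 4 is expected to give about 16000 nM in this assay, between 7000 nM and 40000 nM. The step this estimate means is a 1.3-fold lower number from compound 3 to compound 4 (0.11 log units; within the scatter).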

Compound 4, half-maximal inhibitory concentration: 7010 nM
Estimate against measurement, compound 4: 2.3-fold (0.36 log units) above; the measured number falls inside the stated range.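

In this assay the step is a 3.0-fold lower number from compound 3 to compound 4 (0.47 log units; beyond the scatter), a modest move toward stronger inhibition on this core. Set beside the earlier step on the other core, the two do not differ by more than the scatter: the same change on two cores in this assay, a 1.3-fold lower number (0.13 log units; within the scatter) from compound 1 to compound 2 and a 3.0-fold lower number (0.47 log units; beyond the scatter) from compound 3 to compound 4, 2.2-fold (0.34 log units) apart, within the scatter of two such steps. For the compounds shown here, the change can therefore be said to carry across these two cores without a measurable difference in size, but only the step on the core of compound 3 stands beyond the scatter by itself, and two pairs cannot establish a general rule or explain the shift.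

As far as these compounds go, it remains open whether the same change would act alike on a core carrying an amine or a carboxylic acid. The compounds shown also leave open how the change behaves on any other read-out.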